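The compounds below may be only part of what the source reports. "The series", "measured", "known", "first", "only" and "open" are said of these compounds alone.

In a functional assay on MGC-803 cells (Homo sapiens) for inhibition, read by MTT assay, with a stated time of 48 h (a lower number here means a stronger inhibitor, a higher number a weaker inhibitor), three compounds sharing one core have been measured. Compound 1 (`COc1ccc(CN(C(=O)C(C)Br)c2cc(OC)c(OC)c(OC)c2)cc1O`) gives 120 nM in this series, and compound 2 (`COc1ccc(CN(C(=O)CN=[N+]=[N-])c2cc(OC)c(OC)c(OC)c2)cc1O`) gives 120 nM as well. Compound 3 (`COc1ccc(CN(C(=O)/C=C/CBr)c2cc(OC)c(OC)c(OC)c2)cc1O`) gives 71 nM and so stands within the scatter of both. Compound 4 (`COc1ccc(CN(C(=O)C2CC2)c2cc(OC)c(OC)c(OC)c2)cc1O`) has not yet been measured. It carries cyclopropyl in place of 3-bromoprop-1-en-1-yl on a carbonyl carbon. Every measured step at that carbonyl carbon is small: the readings are no change at the digits printed from compound 1 to compound 2 (within the scatter) and a 1.7-fold lower number from compound 1 to compound 3 (0.23 log units; within the scatter) and a 1.7-fold lower number from compound 2 to compound 3 (0.23 log units; within the scatter) and all of them stay within the scatter. None of these steps brings in a ring, which leaves the case for cyclopropyl indirect. Even so, no step beyond the scatter is expected in this assay for this change. The expected change is a 1.7-fold higher number from compound 3 to compound 4 (0.23 log units; within the scatter) as estimated, with a wide margin on either side. For compound 4 the estimated value is 120 nM with an expected range from 35 nM to 450 nM for four of five measurements.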

Compound 4, half-maximal inhibitory concentration: 59 nM
Estimate against measurement, compound 4: 2.0-fold (0.31 log units) above; the measured number falls inside the stated range.
By their numbers in this assay, from the lowest: compounds 4, 3, 1 and 2 (each within the scatter of the next, the first and the last beyond it).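

In this assay, within the data shown here, the first ring at this carbonyl carbon, cyclopropyl, holds the level of the unsaturated bromide, with a 1.2-fold lower number from compound 3 to compound 4 (0.08 log units; within the scatter) as the reading, and the same ring gives the first steps at this position to pass beyond the scatter, namely a 2.0-fold lower number from compound 2 to compound 4 (0.31 log units; beyond the scatter) and a 2.0-fold lower number from compound 1 to compound 4 (0.31 log units; beyond the scatter), both modest. Compound 4 also carries neither bromine nor azide on this carbonyl carbon, so among these four compounds neither is required for a number in this range. Nothing available here accounts for these steps.

As far as these compounds go, whether a larger carbon ring such as cyclobutyl or cyclohexyl, or a ring bearing an amine, would hold this level remains open. A plain ethyl chain at the same carbonyl carbon, which would separate the ring from its carbon count, is also absent from the compounds shown.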